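This account rests on a few compounds, and the source may have more. Where it says the series, first, only, none or still open, it means among the compounds named here.

Compound 1 `CN1CCN(CCCN(C(=O)Nc2ccc(F)c(Cl)c2)C2CCc3ccccc3C2)CC1`: 380 nM in an assay on CHO cells for binding affinity to melanin-concentrating hormone receptor 1 (Homo sapiens); a higher number here means a weaker inhibitor, a lower number a stronger inhibitor
Compound 2 `COc1ccc2c(c1)CCC(N(CCCN1CCN(C)CC1)C(=O)Nc1ccc(F)c(Cl)c1)C2`: 190 nM in this assay

Compound 1 stands at the highest of the two numbers in this assay. Its nearest neighbour is compound 2, and the step of a 2.0-fold lower number from compound 1 to compound 2 (0.30 log units; within the scatter) is within the scatter, so the two cannot be told apart. Compound 3 `COc1ccc2c(c1)CC(N(CCCN1CCN(C)CC1)C(=O)Nc1ccc(F)c(Cl)c1)CC2` differs from compound 1 by methoxy in place of hydrogen on an aromatic carbon. Among the measured compounds shown here, the only measured step that bears on this change is the one from compound 1 to compound 2, in which a methoxy replaced a hydrogen on a different aromatic carbon of the same ring of the shared core, and that step stayed within the scatter. For the measured compounds named here, no other compound speaks to a methoxy on this carbon. The step from compound 1 to compound 3 in this assay is therefore expected to be small, a 1.3-fold lower number from compound 1 to compound 3 (0.10 log units; within the scatter), with no clear direction beyond the scatter. Compound 3 is estimated at 300 nM, in the range 120 nM to 750 nM.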

Compound 3, inhibition constant: 92 nM
For compound 3 the middle estimate is 3.3-fold (0.51 log units) above the measured one; measured number below the stated range.
By their numbers in this assay, from the lowest: compound 3; then compounds 2 and 1 (each within the scatter of the next).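

In this assay, methoxy in place of hydrogen on this aromatic carbon, which is meta to a fused ring and para to a fused ring, gives a 4.1-fold lower number from compound 1 to compound 3 (0.62 log units; beyond the scatter). This is the first step shown for a methoxy on the ring of the shared core that lies beyond the scatter, whereas a 2.0-fold lower number from compound 1 to compound 2 (0.30 log units; within the scatter), with the methoxy on a different carbon of that ring, stayed within it. Nothing measured here accounts for the step at this carbon.

The compounds shown leave open whether this carbon favours methoxy in particular or whether a hydroxyl, an ethoxy or a fluorine there would give a similar step. They also leave open whether the step would persist with a piperidine in place of the methylpiperazine at the end of the chain.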